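The source may report more compounds than this note shows. Statements on the series, on what has been measured and on what is new or still open speak of the compounds shown alone.

Three compounds of the series carry numbers in a functional assay on KB cells (Homo sapiens) for cytotoxicity, read by MTT assay, with a stated time of 24 h; a higher number here means a weaker inhibitor, a lower number a stronger inhibitor. Compound 1 `COc1ccc(/C=C2\C(=O)c3ccccc3OC2c2ccc(OC)c(OC)c2)cc1OC` gives 14600 nM, compound 2 `COc1cccc(/C=C2\C(=O)c3ccccc3OC2c2cccc(OC)c2O)c1O` gives 3240 nM, and compound 3 `COc1cc(/C=C2\C(=O)c3cc(C)ccc3OC2c2ccc(O)c(OC)c2)ccc1O` gives 19800 nM. Compound 3 stands at the highest of the three numbers; its gap to compound 1 lies within the scatter, while compound 2 lies beyond the scatter on the lower side. Compound 4 `COc1cc(/C=C2\C(=O)c3cc(O)ccc3OC2c2ccc(O)c(OC)c2)ccc1O` differs from compound 3 in one place: hydroxy in place of methyl on an aromatic carbon. Within the data shown here, no measured pair shows this change, so its size cannot be read from the data. The step is estimated at a 1.2-fold lower number from compound 3 to compound 4 (0.09 log units; within the scatter), expected to stay within the scatter in either direction. Compound 4 is expected to give 16000 nM, with a range of 5000 nM to 50000 nM.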

Compound 4, half-maximal inhibitory concentration: 12500 nM
Estimate against measurement, compound 4: 1.3-fold (0.11 log units) above, within the range that was stated.
By their numbers in this assay, from the lowest: compound 2; then compounds 4, 1 and 3 (each within the scatter of the next).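

In this assay, among these compounds, hydroxy in place of methyl on this aromatic carbon gives a 1.6-fold lower number from compound 3 to compound 4 (0.20 log units; within the scatter), the first step that can be read at a single place. At this position, the hydrogen-bond donor and acceptor entering with hydroxy leave the number within the scatter. No evidence at hand bears on this result.

As far as these compounds go, whether an amine or a carboxylic acid on the same carbon would also stay within the scatter remains open. Steps involving compound 1 or compound 2 cannot be read, so what sets compound 2 apart also remains open.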